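Swapping Fluoro for Methyl on a Shared Core

This account rests on a few compounds, and the source may have more. Where it says the series, first, only, none or still open, it means among the compounds named here.

Measured compounds:
compound 1 `Cc1cc(-c2nc3cc(F)ccc3o2)ccc1NC(=O)CCl` — > 100000 nM
compound 2 `CN(C)CCN1CCN(CC(=O)Nc2ccc(-c3nc4cc(F)ccc4o3)cc2)CC1` — 20800 nM

In a functional assay on MCF7 cells (Homo sapiens) for cytotoxicity, read by MTT assay, with a stated time of 24 h (a lower number here means a stronger inhibitor, a higher number a weaker inhibitor), compound 1 reaches only the limit of the assay, > 100000 nM, so its position on the numbers is an upper bound rather than a value, matching (the limit of > 100000 nM in this assay, at which 1 of the 2 values shown sits). In this assay compound 2 gives 20800 nM, a weak number that stands apart from compound 1 and shares only the core with it.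

Compound 3 `Cc1ccc2oc(-c3ccc(NC(=O)CCl)c(C)c3)nc2c1` differs from compound 1 in one place: methyl in place of fluoro on an aromatic carbon. For the measured compounds named here, no measured pair shows what this exchange does, and the only anchor is the limit of compound 1. Methyl in place of fluoro is expected to leave the number within the scatter, and the step of a number no higher from compound 1 to compound 3 (the limit leaves the size open) is estimated as no change beyond it. Compound 3 is therefore expected at 100000 nM, within 30000 nM to 300000 nM, most likely again reported as a limit.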

Compound 3, half-maximal inhibitory concentration: 96500 nM
For compound 3 the middle estimate is 1.0-fold (0.02 log units) above the measured one; the measured number falls inside the stated range.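

In this assay, for the compounds shown here, compound 3 gives 96500 nM, so this aromatic carbon now carries a measured number, which the earlier compounds did not supply for it. Compound 1 holds only a limit here, > 100000 nM. Methyl in place of fluoro gives an at least 1.0-fold lower number from compound 1 to compound 3 (0.01 log units; that floor lies within the scatter), so the exchange can be read only as a floor that shows no change beyond the scatter, and its true size stays open because one end of the step is a limit: the limit of > 100000 nM in this assay, at which 1 of the 3 values shown sits.

The compounds shown leave open whether a different group on this aromatic carbon, such as an amine or a methoxy group, would move the number at all. They also leave open whether methyl in place of fluoro would do the same on the core of compound 2, with its longer side chain.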